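Replacing 4-nitrophenyl with pyridin-4-yl in compound 3

The compounds below may be only part of what the source reports. "The series", "measured", "known", "first", "only" and "open" are said of these compounds alone.

Of the compounds shown here, three have been measured so far in a physicochemical assay for lipophilicity, read by LC-MS, using the shake flask method, in phosphate buffer, measured as octanol-water partition, with a stated time of 2 h, at pH 7.4 (a lower number here means a more polar compound, a higher number a more lipophilic compound), and they read as follows.
- Compound 1 `O=[N+]([O-])c1ccc(-n2cc(CO[C@H]3O[C@H](CO)[C@@H](O)[C@H](O)[C@@H]3O)nn2)cc1` gives -0.16
- Compound 2 `OC[C@H]1O[C@H](OCc2cn(-c3cccc(F)c3)nn2)[C@@H](O)[C@@H](O)[C@@H]1O` gives 0.18
- Compound 3 `O=[N+]([O-])c1ccc(-n2cc(CCO[C@H]3O[C@H](CO)[C@@H](O)[C@H](O)[C@@H]3O)nn2)cc1` gives -0.3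

In this assay compound 3 at -0.3 sits within the usual scatter of compound 1 at -0.16 and the two share the lower end of the three numbers. Compound 2 at 0.18 lies higher than compound 3, beyond the scatter.

The next compound is compound 4 `OC[C@H]1O[C@H](OCCc2cn(-c3ccncc3)nn2)[C@@H](O)[C@@H](O)[C@@H]1O` and it differs from compound 3 in one place pyridin-4-yl in place of 4-nitrophenyl on an aromatic nitrogen with pyridin-4-yl in place of 4-nitrophenyl on an aromatic nitrogen.

Within the data shown here, only one measured step bears on this place, a number 0.34 log units higher from compound 1 to compound 2 (beyond the scatter) and it is modest. That step removes the same 4-nitrophenyl, but a different group enters, so it guides the expected size more than the direction. Among the measured compounds shown here, no measured compound has a ring with a hetero atom here, which leaves the expected downward direction uncertain.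

The expected change is a number 0.45 log units lower from compound 3 to compound 4 (beyond the scatter) in this assay with wide margins. For compound 4 the estimated value is -0.75 with an expected range from -1.3 to -0.3 and the measurement is still to come.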

Compound 4, distribution coefficient: < -1.5
Compound 4: only a limit was reported; the forecaster's own chance of this, stated with the estimate: 2%; at least 0.75 log units between middle value and limit.
By their numbers in this assay, from the lowest: compounds 3 and 1 (each within the scatter of the next); then compound 2. At a limit, below all of these: compound 4.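

In this assay, among these compounds, the group on the aromatic nitrogen proves able to move the reading much further than the earlier compounds showed: the new step is a number at least 1.20 log units lower from compound 3 to compound 4 (beyond the scatter), a large one, whereas the only earlier step at this place was the modest a number 0.34 log units higher from compound 1 to compound 2 (beyond the scatter). Among the compounds shown here, it is also the first step here to a ring with a hetero atom, and it runs downward, while the change from 4-nitrophenyl to 3-fluorophenyl ran upward, although that earlier step was read on the core of compound 1 and not on that of compound 3. The reading for compound 4 is a limit and not a number, so the step gives only a minimum size: the limit of < -1.5 in this assay, at which 1 of the 4 values shown sits.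

On these data alone, how far the true value of compound 4 lies past that limit remains open, as does whether the step belongs to the ring nitrogen of pyridin-4-yl or to the departure of the 4-nitrophenyl group. A plain phenyl group or a pyridin-3-yl group at this place would help to separate the two, and the same exchange on the core of compound 1 would show whether the step carries over.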